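The source may report more compounds than this note shows. Statements on the series, on what has been measured and on what is new or still open speak of the compounds shown alone.

In a functional assay on MOLT-4 cells (Homo sapiens) for cytotoxicity, read by sulforhodamine B assay, with a stated time of 48 h, tested at 1 uM (on this read-out higher numbers stand for a weaker effect at the one concentration tested and lower numbers for a stronger effect), compound 1, `COc1cc(C)cc(-c2c(-c3ccnc(-c4ccc(N(C)C)cc4)c3)cnn2CC#N)c1`, gives -2%, a weak effect at the single concentration tested. Among the measured compounds shown here, compound 2, `COc1cc(C)cc(-c2nn(CC#N)cc2-c2ccnc(-c3ccc(N(C)C)cc3)c2)c1`, gives 13% in this assay, which is the higher of the two numbers known here and lies above compound 1 by a gap beyond the scatter of repeated measurements. The two compounds are not joined by a single structural step, so only their two values can be compared, and both point to little cytotoxicity on these cells.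

Compound 3, `Cc1cc(O)cc(-c2nn(CC#N)cc2-c2ccnc(-c3ccc(N(C)C)cc3)c2)c1`, has not yet been measured in this assay. Its difference from compound 2 is hydrogen in place of methyl on an oxygen on an aromatic ring. For the measured compounds named here, no measured pair in this set shows what this change does here, so the expectation rests on compound 2 alone. Compound 3 is expected to give about 10% in this assay, within a range of -10% to 30%. The step expected from compound 2 to compound 3, a number 3 percentage points lower from compound 2 to compound 3 (within the scatter), is estimated to be no larger than the scatter, in no particular direction.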

Compound 3, a percentage reported as activity, at one concentration (the size of the read-out at that concentration, not a potency): 11%
Beside the measured number, compound 3's estimate is 1 percentage points below it, and the stated range covers the measured number.
By their numbers in this assay, from the lowest: compound 1; then compounds 3 and 2 (each within the scatter of the next).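

Among the compounds shown here, compound 3 gives the first reading at this position: in this assay, the exchange of methoxy for hydroxy within the 3-methoxy-5-methylphenyl group appears as a number 2 percentage points lower from compound 2 to compound 3 (within the scatter). Hydrogen can therefore take the place of methyl on this oxygen on an aromatic ring without a difference that can be told from the scatter, so this single pair gives no sign that the methyl on the oxygen matters for the read-out at the one concentration tested. Nothing further accompanies this result that would bear on how to interpret it.

What the compounds shown leave open is whether this tolerance extends beyond hydrogen and methyl on this oxygen, for example to a longer chain such as ethoxy, or whether an amine or a carboxylic acid in place of the hydroxy group would read the same in this assay. As far as these compounds go, it also remains open whether the same exchange of methoxy for hydroxy would read the same on the core of compound 1, and, with a single concentration for each compound, how potency compares across the set.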